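Nitro compound, double bond drawn E or Z

This account rests on a few compounds, and the source may have more. Where it says the series, first, only, none or still open, it means among the compounds named here.

In a functional assay on HCT-116 cells (Homo sapiens) for inhibition (a higher number here means a weaker inhibitor, a lower number a stronger inhibitor), compound 3 (`COc1ccc(/C=C/c2ccc3ccccc3c2)cc1[N+](=O)[O-]`) reads > 5000 nM as a limit and not a number. Compound 2 (`COc1ccc(/C=C/c2ccc3ccccc3c2)cc1F`) reads > 5000 nM and that too is a limit. Compound 3 therefore stands at the limit of > 5000 nM in this assay, at which 2 of the 3 values shown sit, and no exact place can be given for it. Among the measured compounds shown here, the one measured step is a step that the two limits leave unreadable from compound 2 to compound 3 and it offers no size to carry forward.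

The open question is compound 4 (`COc1ccc(/C=C\c2ccc3ccccc3c2)cc1[N+](=O)[O-]`), where the structural change is this: the two compounds have the same atoms and bonds and differ only in configuration as drawn: 1 of 1 stereo elements differ; a double bond is drawn E in compound 3 and Z in compound 4 and that is the whole difference. The nearest guide is compound 1 (`COCCOc1cc(/C=C\c2ccc3ccccc3c2)ccc1OC`), which also has its double bond drawn Z and differs from compound 4 elsewhere. In this assay compound 1 gives a true number of 2990 nM. Resting on compound 1 at 2990 nM as the only readable value, the move from E to Z is expected to give a stronger inhibitor, although one example supports this only weakly. The expected size is an at least 5.0-fold lower number from compound 3 to compound 4 (0.69 log units; beyond the scatter) and it remains a rough estimate. For compound 4 the estimate is 1000 nM with an expected range from 100 nM to 5000 nM and a real chance of another limit.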

Compound 4, half-maximal inhibitory concentration: > 20000 nM
Compound 4 gave a limit, no number; the forecaster's own chance of this, stated with the estimate: 25%; middle value at least 20-fold (1.30 log units) from the limit.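

In this assay, a double bond drawn Z does not by itself give a readable number: with the double bond drawn Z in both compounds, nitro in place of 2-methoxyethoxy on an aromatic carbon gives an at least 6.6-fold higher number from compound 1 to compound 4 (0.82 log units; beyond the scatter). Compound 4 therefore sits at a limit and not at a number, the highest limit among the compounds shown: the limit of > 20000 nM in this assay, at which 1 of the 4 values shown sits. Compound 3 is also a limit, and the steps that join limits to one another cannot be read, so the change from E to Z has no size: the limit of > 5000 nM in this assay, at which 2 of the 4 values shown sit.

On these data alone, whether the configuration of the double bond matters at all in the nitro compounds remains open, as this pair isolates that one change but gives no number on either side: the fact that compounds 3 and 4 differ only in the configuration as drawn Also open is how an amine or a hydroxyl in place of nitro on the Z compound would read, and so whether any group other than 2-methoxyethoxy at that carbon gives a true number in this assay.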